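Working notes: aryl change from compound 1 to compound 3

A few compounds are considered here, and "the series" means these few. Any claim that something is new, unique, unknown or untested is made for them only; others in the source may bear on it.

Measured compounds:
compound 1 `COc1cccc(/C=C/C(=O)c2ccc(OC)c3c2OC(C)(C)C=C3)c1`, in a functional assay on SW-620 cells (Homo sapiens) for antiproliferative activity, read by MTT assay, with a stated time of 24 h; a lower number here means a stronger inhibitor, a higher number a weaker inhibitor: > 10000 nM
compound 2 `COc1ccc(C(=O)/C=C/c2cc(OC)c(OC)c(OC)c2)c2c1C=CC(C)(C)O2`, in this assay: 9150 nM

The value for compound 1 is a limit of the assay, not a number; compound 1 stands at that limit, as the limit of > 10000 nM in this assay, at which 1 of the 2 values shown sits, shows. Going by the values given here, compound 2 supplies the only numeric value.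

Compound 3 `COc1ccc(/C=C/C(=O)c2ccc(OC)c3c2OC(C)(C)C=C3)c(F)c1` differs from compound 1 by 2-fluoro-4-methoxyphenyl in place of 3-methoxyphenyl on a double-bonded chain carbon bound to a double-bonded chain carbon. No measured step of this kind exists among the shown compounds, so no direction can be read from the data. The step from compound 1 to compound 3 is expected to stay within the usual scatter, a number no higher from compound 1 to compound 3 (the limit leaves the size open). Compound 3 is expected near 10000 nM, in the range 4000 nM to 30000 nM.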

Compound 3, half-maximal inhibitory concentration: 6570 nM
Beside the measured number, compound 3's estimate is 1.5-fold (0.18 log units) above it, within the range that was stated.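

With 2-fluoro-4-methoxyphenyl in place of 3-methoxyphenyl on a double-bonded chain carbon bound to a double-bonded chain carbon, the series shows its first step at this position: an at least 1.5-fold lower number from compound 1 to compound 3 (0.18 log units; that floor lies within the scatter). In this assay compound 3 gives 6570 nM, so this position now has a numeric value on the core of compound 1. The true size of the step remains unknown because the value of compound 1 is a limit of the assay, not a number: the limit of > 10000 nM in this assay, at which 1 of the 3 values shown sits.

The compounds shown do not separate the added fluorine from the changed place of the methoxy group. On these data alone, how an amine or a carboxylic acid on this aryl ring would read also remains open.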